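This account rests on a few compounds, and the source may have more. Where it says the series, first, only, none or still open, it means among the compounds named here.

Notes on the series. Within the data shown here, compound 2 `COC(=O)[C@H](CC(C)C)NC(=O)c1ccc(OC[C@H]2COc3ccccc3O2)cc1-c1ccccc1C` gives the lowest of the two numbers so far: in a functional assay (HSMC cells, Homo sapiens) for antiproliferative activity, with a stated time of 72 h (on this read-out higher numbers stand for weaker inhibition and lower numbers for stronger inhibition), compound 2 gives 3000 nM, while compound 1 `COC(=O)CNC(=O)c1ccc(OC[C@H]2COc3ccccc3O2)cc1-c1ccccc1OC` sits higher in this assay at 71000 nM, a gap beyond the scatter; the two differ in more than one place, so nothing is drawn from it. Compound 3 `COC(=O)[C@H](CC(C)C)NC(=O)c1ccc(OC[C@H]2COc3ccccc3O2)cc1-c1ccccc1OC` differs from compound 2 only by methoxy in place of methyl on an aromatic carbon. Among the measured compounds shown here, no measured pair shows this change alone. A small step is expected in this assay, likely toward weaker inhibition or none beyond the scatter, with a 1.7-fold higher number from compound 2 to compound 3 (0.22 log units; within the scatter) as the expected size. Compound 3 is estimated at 5000 nM, between 1500 nM and 16000 nM.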

Compound 3, half-maximal inhibitory concentration: 32000 nM
The estimate for compound 3 lay 6.4-fold (0.81 log units) below the measured number; measured number above the stated range.
By their numbers in this assay, from the lowest: compound 2; then compound 3; then compound 1.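

In this assay the swap of methoxy for methyl on this aromatic carbon, ortho to a large group, is no small change: the data give an 11-fold higher number from compound 2 to compound 3 (1.03 log units; beyond the scatter) for this change alone, so 2-methylphenyl holds the stronger inhibition of this pair. Isobutyl in place of hydrogen on the saturated chain carbon also counts, with a 2.2-fold lower number from compound 1 to compound 3 (0.35 log units; beyond the scatter) as a modest step on the 2-methoxyphenyl background. Nothing at hand bears on the reason for either step.

Open, as far as these compounds go, is whether ethyl or chlorine on the same aromatic carbon would track methyl or methoxy. Also open, from the compounds shown here alone, is whether a carboxylic acid in place of the methyl ester would preserve these steps.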